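A few compounds are considered here, and "the series" means these few. Any claim that something is new, unique, unknown or untested is made for them only; others in the source may bear on it.

Measured so far in a functional assay on Jurkat cells (Homo sapiens) for antiproliferative activity, read by MTT assay, with a stated time of 72 h; on this read-out higher numbers stand for weaker inhibition and lower numbers for stronger inhibition:
Compound 1, `COc1cc(-n2ncnc2-c2ccc(F)cc2)cc(OC)c1OC`, gives only a limit of the assay: > 10000 nM.
Compound 2, `COc1cc(-n2ncnc2-c2ccc(C)cc2)cc(OC)c1OC`, gives 300 nM.
Compound 3, `COc1cc(-c2ncnn2-c2cccc([N+](=O)[O-])c2)cc(OC)c1OC`, gives only a limit of the assay: > 10000 nM.

For the measured compounds named here, compound 2 therefore holds the only number in this assay; the two other values shown are limits. Going by the values given here, the single measured step, an at least 33-fold lower number from compound 1 to compound 2 (1.52 log units; beyond the scatter), is large, and because it starts from the assay edge the limit of > 10000 nM in this assay, at which 2 of the 3 values shown sit, its true size is only bounded from below. Compound 4, `COc1cc(-n2ncnc2-c2ccc(Cl)cc2)cc(OC)c1OC`, is not yet measured. It differs from compound 2 by chloro in place of methyl on an aromatic carbon. Among the compounds with values here, the measured step bears on this change only indirectly: chloro is neither the group that left nor the group that entered in that step, so no measured pair fixes the direction of the change. Compound 4 is expected to stay close to compound 2, with a 1.7-fold higher number from compound 2 to compound 4 (0.22 log units; within the scatter) as the expected step in this assay. For compound 4 the estimate is 500 nM, within a range of 150 nM to 2500 nM.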

Compound 4, half-maximal inhibitory concentration: > 10000 nM
Compound 4 ended at the assay's limit (the forecaster's own chance of this, stated with the estimate: 10%); middle value at least 20-fold (1.30 log units) from the limit.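

In this assay, the place para to a large group does not accept chloro for methyl: an at least 33-fold higher number from compound 2 to compound 4 (1.52 log units; beyond the scatter). Alongside an at least 33-fold lower number from compound 1 to compound 2 (1.52 log units; beyond the scatter), methyl is now the only one of the three groups at this place with a measured number, while fluoro and chloro both end at a limit, and the step from compound 1 to compound 4 cannot be read. Both readable steps are therefore bounded from one side only, with their true size set by the assay edge: the limit of > 10000 nM in this assay, at which 3 of the 4 values shown sit.

Open, as far as these compounds go, is whether the activity is specific to methyl at this place, or whether a longer chain such as ethyl, or an amine, also gives a measured number. Also open, from the compounds shown here alone, is how far compound 1 and compound 4 lie beyond the limit.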